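The compounds below may be only part of what the source reports. "The series", "measured", "known", "first", "only" and "open" are said of these compounds alone.

Three measured compounds share one nucleoside core. Compound 1 `COc1nc(ONC(=O)OCc2ccccc2)nc2c1ncn2[C@@H]1O[C@H](CO)[C@@H](O)[C@@]1(C)O` is the largest of them. In an ADME assay on Vero cells (Chlorocebus sabaeus) for cytotoxicity, with a stated time of 3 days (on this read-out higher numbers stand for lower toxicity in this test and lower numbers for higher toxicity in this test), compound 1 reaches only the assay limit of > 100000 nM. Compound 2 `COc1nc(O)nc2c1ncn2[C@@H]1O[C@H](CO)[C@@H](O)[C@@]1(C)O` follows from it through a step that the two limits leave unreadable from compound 1 to compound 2, a step with hydrogen in place of (benzyloxycarbonyl)amino on an oxygen on an aromatic ring. In this assay compound 2 likewise gives the limit of > 100000 nM. Compound 3 `C[C@@]1(O)[C@H](O)[C@@H](CO)O[C@H]1n1cnc2c(N)nc(O)nc21` follows through a step that the two limits leave unreadable from compound 2 to compound 3, amino in place of methoxy on an aromatic carbon. In this assay compound 3 again sits at the limit of > 100000 nM. Both steps are unreadable, as the limit of > 100000 nM in this assay, at which 3 of the 3 values shown sit, shows, so compound 3 stands only at a limit alongside the other two. Compound 4 `C[C@@]1(O)[C@H](O)[C@@H](CO)O[C@H]1n1cnc2c(N)nc(F)nc21` differs by fluoro in place of hydroxy on an aromatic carbon. Among the measured compounds shown here, no measured step bears on this exchange, and the measured steps themselves give no readable size. One therefore expects no shift beyond the scatter, a step that the limit leaves unreadable from compound 3 to compound 4, for compound 4. Compound 4 is estimated at 150000 nM, from 60000 nM to 400000 nM.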

Compound 4, half-maximal cytotoxic concentration: > 100000 nM
Compound 4: no number, only a limit; the forecaster's own chance of this, stated with the estimate: 75%; the middle value does not contradict the limit.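

No step can be read from compound 3 to compound 4, as both stand only at a limit in this assay: the limit of > 100000 nM in this assay, at which 4 of the 4 values shown sit. As far as these compounds go, how far any of the four compounds lies from that limit stays open, and with it the size of each exchange.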